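The source may report more compounds than this note shows. Statements on the series, on what has been measured and on what is new or still open speak of the compounds shown alone.

In a functional assay on NALM-6 cells (Homo sapiens) for cytotoxicity, read by luminescence and CellTiter-Glo, with a stated time of 3 days (a lower number here means a stronger inhibitor, a higher number a weaker inhibitor), compound 1 (`O=C(Nc1cc(F)cc(F)c1)c1ccc2cccnc2c1O`) gives 310 nM, compound 2 (`O=C(Nc1cc(C(F)(F)F)cc(C(F)(F)F)c1)c1cc(Br)c(-c2ccccc2)cc1O`) gives 840 nM, and compound 3 (`O=C(Nc1cc(C(F)(F)F)cc(C(F)(F)F)c1)c1ccc(Br)cc1O`) gives 1200 nM. Compound 3 thus lies within the scatter of compound 2, and its number is clearly higher than that of compound 1. Compound 4 (`O=C(Nc1cc(C(F)(F)F)cc(C(F)(F)F)c1)c1ccc(-c2ccccc2)cc1O`) carries phenyl in place of bromo on an aromatic carbon, meta to a hydroxy group and para to a large group: phenyl in place of bromo on an aromatic carbon. Within the data shown here, no measured pair isolates this change. Compound 2 carries both phenyl and bromo and gives 840 nM, so no step beyond the scatter is expected in this assay. The estimated step is a 1.5-fold lower number from compound 3 to compound 4 (0.18 log units; within the scatter). The expected value for compound 4 is 800 nM, with an estimated range from 300 nM to 2000 nM.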

Compound 4, half-maximal inhibitory concentration: 1580 nM
Beside the measured number, compound 4's estimate is 2.0-fold (0.30 log units) below it; low and high end bracket the measured number.
By their numbers in this assay, from the lowest: compound 1; then compounds 2, 3 and 4 (each within the scatter of the next).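

In this assay, phenyl in place of bromo on an aromatic carbon, meta to a hydroxy group and para to a large group, gives a 1.3-fold higher number from compound 3 to compound 4 (0.12 log units; within the scatter) and so stays within the scatter, even though the six-membered aromatic ring adds heavy atoms. Hydrogen in place of bromo gives a 1.9-fold higher number from compound 2 to compound 4 (0.27 log units; within the scatter) with phenyl present, which is also within the scatter. No measurement bears on why these changes leave the number within the scatter. As far as these compounds go, whether an amine or a carboxylic acid at this position would produce a step beyond the scatter in this assay remains open.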